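A few compounds are considered here, and "the series" means these few. Any claim that something is new, unique, unknown or untested is made for them only; others in the source may bear on it.

Working notes on the series. Compound 1 `O=C(NCc1ccccc1)c1cn(-c2ccccc2)nc1-c1cccnc1` and compound 2 `COc1ccc(OC(=O)c2cn(-c3ccccc3)nc2-c2cccnc2)cc1` share one core and differ only at the carbonyl carbon, which carries benzylamino in compound 1 and 4-methoxyphenoxy in compound 2. In a functional assay on MDA-MB-231 cells (Homo sapiens) for cytotoxicity, read by MTT assay, with a stated time of 48 h (on this read-out higher numbers stand for weaker inhibition and lower numbers for stronger inhibition), compound 1 gives > 100000 nM, a limit of the assay and not a number. In this assay compound 2 gives > 100000 nM, likewise a limit rather than a number. Compound 2 therefore stands at the limit of > 100000 nM in this assay, at which 2 of the 2 values shown sit, and the measured numbers place it nowhere more precisely than that. Compound 3 `CC(C)c1cccc(OC(=O)c2cn(-c3ccccc3)nc2-c2cccnc2)c1` is still to be measured in this assay; it differs from compound 2 by 3-isopropylphenyl in place of 4-methoxyphenyl on an oxygen next to a carbonyl group. Among the measured compounds shown here, only one measured step touches this position: a step that the two limits leave unreadable from compound 1 to compound 2, and its size cannot be read. With both known values sitting at the same limit, no direction is readable, and the expected step is a step that the limit leaves unreadable from compound 2 to compound 3, with a further limit the most likely outcome. Compound 3 is accordingly estimated at 150000 nM, with a range from 30000 nM to 1000000 nM.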

Compound 3, half-maximal inhibitory concentration: > 100000 nM
Compound 3: no number, only a limit; the forecaster's own chance of this, stated with the estimate: 75%; the middle value does not contradict the limit.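

In this assay, among the compounds shown here, compound 3 gives > 100000 nM, a limit of the assay and not a number, so neither the step from compound 2 to compound 3 nor the one from compound 1 to compound 2 can be read. The compounds shown leave open whether any group on this carbonyl gives a measurable value, with everything so far at a single limit: the limit of > 100000 nM in this assay, at which 3 of the 3 values shown sit.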